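The compounds below may be only part of what the source reports. "The series", "measured", "known", "first", "only" and "open" are said of these compounds alone.

Compound 2 `O=C(NCCNc1nccc(-c2c(-c3cccc(F)c3)nc3sccn23)n1)c1ccc(C(F)(F)F)cc1` 8710 nM
Compound 1 `O=S(=O)(NCCCNc1nccc(-c2c(-c3cccc(F)c3)nc3sccn23)n1)c1cccc(F)c1` 13700 nM

In a functional assay on A-375 cells (Homo sapiens) for cytotoxicity, read by MTT assay (on this read-out higher numbers stand for weaker inhibition and lower numbers for stronger inhibition), compound 2 gives 8710 nM, the lowest of the two numbers shown; the nearest is compound 1, whose value of 13700 nM lies within the scatter of it, so the two cannot be ordered. Compound 3 `O=C(NCCNc1nccc(-c2c(-c3cccc(F)c3)nc3sccn23)n1)c1ccccc1` differs from compound 2 by hydrogen in place of trifluoromethyl on an aromatic carbon. For the measured compounds named here, no measured pair shows this change, so no step beyond the scatter is expected in either direction. Compound 3 is therefore estimated at 10000 nM, between 4000 nM and 25000 nM, an expected step of a 1.1-fold higher number from compound 2 to compound 3 (0.06 log units; within the scatter).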

Compound 3, half-maximal inhibitory concentration: 5060 nM
Compound 3: middle estimate off by 2.0-fold (0.30 log units), on the high side; the measured number falls inside the stated range.
By their numbers in this assay, from the lowest: compounds 3, 2 and 1 (each within the scatter of the next, the first and the last beyond it).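

In this assay, going from 4-(trifluoromethyl)phenyl to phenyl gives a 1.7-fold lower number from compound 2 to compound 3 (0.24 log units; within the scatter), so the trifluoromethyl on this aromatic carbon can go with no step beyond the scatter. Benzamido in place of (((3-fluorophenyl)sulfonyl)amino)methyl gives a 2.7-fold lower number from compound 1 to compound 3 (0.43 log units; beyond the scatter), the only step here beyond the scatter, and a modest one. No measurement is available that bears on the reason for either step. On these data alone, whether a methoxy group, a chlorine or an amine on that aromatic carbon would move the number remains open. So does the effect of a longer chain leading to the benzamide nitrogen.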